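The source may hold more compounds than are shown below. What is called first, only, known or untested is meant among the compounds shown, and "the series" means these compounds.

Measured compounds:
Compound 1, `CCCCCc1ccc(NS(=O)(=O)c2ccc(N3CCNC3=O)cc2)cc1`, gives 990 nM.
Compound 2, `COc1ccccc1NS(=O)(=O)c1ccc(N2CCNC2=O)cc1`, gives 550 nM.
Compound 3, `COc1cccc(NS(=O)(=O)c2ccc(N3CCNC3=O)cc2)c1`, gives 120 nM.

These three share a core and differ only in the aryl group on the sulfonamide nitrogen. In a functional assay on HT-29 cells (Homo sapiens) for antiproliferative activity, read by sulforhodamine B assay, with a stated time of 48 h (a higher number here means a weaker inhibitor, a lower number a stronger inhibitor), compound 1 stands at the highest of the three numbers. Compound 2 lies nearest to it, within the scatter. Compound 3 lies furthest from it, beyond the scatter. For the measured compounds named here, the only step measured between compounds that differ in a single place is a 4.6-fold lower number from compound 2 to compound 3 (0.66 log units; beyond the scatter), and it concerns the position of a methoxy group, not the chain on the ring.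

Compound 4, `O=C1NCCN1c1ccc(S(=O)(=O)Nc2ccccc2)cc1`, differs from compound 1 by hydrogen in place of pentyl on an aromatic carbon. Going by the values given here, no measured step bears directly on this change. Among the compounds with values here, the only guidance is that compound 2 and compound 3, which carry a methoxy group instead of a pentyl, do not give higher numbers than compound 1, and compound 3 gives a number beyond the scatter below it. A small step toward a lower number is therefore thought possible, but it may well fall within the scatter.

Compound 4 is expected to give about 600 nM in this assay, in a range from 200 nM to 2000 nM. The estimate corresponds to an expected step of a 1.7-fold lower number from compound 1 to compound 4 (0.22 log units; within the scatter).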

Compound 4, half-maximal inhibitory concentration: 280 nM
Compound 4: the middle estimate sits 2.1-fold (0.33 log units) above what was measured; low and high end bracket the measured number.
By their numbers in this assay, from the lowest: compound 3; then compounds 4, 2 and 1 (each within the scatter of the next, the first and the last beyond it).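

In this assay, hydrogen in place of pentyl on an aromatic carbon, para to a large group, gives a step beyond the scatter (a 3.5-fold lower number from compound 1 to compound 4 (0.55 log units; beyond the scatter)), so the pentyl chain is not needed for activity in this series and goes with the higher number. Compound 4 also gives the methoxy compounds a reference without a substituent on that ring: compound 3 keeps a lower number than compound 4 by a step beyond the scatter (a 2.3-fold higher number from compound 3 to compound 4 (0.37 log units; beyond the scatter)), whereas the step to compound 2 lies within the scatter (a 2.0-fold lower number from compound 2 to compound 4 (0.29 log units; within the scatter)), so the data do not separate compound 2 from compound 4. Nothing shown here accounts for these steps, and the size of each can only be recorded as it stands.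

As far as these compounds go, what a shorter chain such as ethyl, or an amine or a carboxylic acid, would do on this aromatic carbon stays open. So does how a methoxy group on this same carbon would compare with the pentyl of compound 1 and the hydrogen of compound 4.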